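Series notes: from compound 1 to compound 4

A few compounds are considered here, and "the series" means these few. Any claim that something is new, unique, unknown or untested is made for them only; others in the source may bear on it.

Compound 1 `Cc1c(C(=O)Nc2ccc(C(F)(F)F)cc2)cnn1-c1ccc(F)c(Cl)c1` has been measured in a functional assay with Homo sapiens as the target (a lower number here means a stronger inhibitor, a higher number a weaker inhibitor), where compound 1 gives 1300 nM. Compound 2 `Cc1c(C(=O)Nc2cccc(F)c2)cnn1-c1ccc(F)cc1` gives 3000 nM, and compound 3 `Cc1cccc(NC(=O)c2cnn(-c3ccc(F)cc3)c2C)c1` gives 5700 nM. Among these three numbers compound 1 holds the lowest; the nearest is compound 2 and the furthest compound 3, and both gaps lie beyond the scatter. Among the compounds with values here, the only step between measured compounds that differ in one place is a 1.9-fold higher number from compound 2 to compound 3 (0.28 log units; within the scatter), methyl in place of fluoro on an aromatic carbon.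

Compound 4 `Cc1c(C(=O)Nc2ccc(C(F)(F)F)cc2)cnn1-c1ccc([N+](=O)[O-])cc1` differs from compound 1 in one place: 4-nitrophenyl in place of 3-chloro-4-fluorophenyl on an aromatic nitrogen. Within the data shown here, no measured step bears on a group on an aromatic nitrogen of a five-membered aromatic ring with 2 nitrogen; the one step available concerns an aromatic carbon and stays within the scatter. The data therefore give no ground for expecting a large shift in either direction, and the expected step is a 1.5-fold higher number from compound 1 to compound 4 (0.19 log units; within the scatter), held with wide uncertainty. Compound 4 is estimated at 2000 nM, with a range from 700 nM to 6000 nM.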

Compound 4, half-maximal inhibitory concentration: 5700 nM
Compound 4: middle estimate off by 2.9-fold (0.45 log units), on the low side, within the range that was stated.
By their numbers in this assay, from the lowest: compound 1; then compounds 2, 3 and 4 (each within the scatter of the next).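

In this assay the group on the aromatic nitrogen is not a silent position: 4-nitrophenyl in place of 3-chloro-4-fluorophenyl gives a 4.4-fold higher number from compound 1 to compound 4 (0.64 log units; beyond the scatter) with the rest of the structure held constant. The only earlier step concerned an aromatic carbon and stayed within the scatter, so this is the first change in the series shown to move the number beyond it, and here 3-chloro-4-fluorophenyl gives the lower number. No measurement at hand accounts for this step.

On these data alone, this single change removes chlorine and fluorine and brings in the nitro group together, so the share of each in the step stays open. Also open, as far as these compounds go, is how an unsubstituted phenyl, a 4-aminophenyl or a cyclohexyl group would read on the aromatic nitrogen of the core of compound 1.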